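Trading a Cyclohexyl for an Ethyl on the Side Chain

The source may report more compounds than this note shows. Statements on the series, on what has been measured and on what is new or still open speak of the compounds shown alone.

Of the compounds shown here, three sharing one core have been tested in an assay on THP-1 cells for inhibition of nuclear factor NF-kappa-B complex (Homo sapiens), with stated times of 2 h and 16 h; a higher number here means a weaker inhibitor, a lower number a stronger inhibitor. Compound 1 `CC(C)CCCOc1cccc(O)c1C(=O)/C=C/c1ccc(O)cc1` gives 11000 nM. Compound 2 `COc1cccc(OCCC(C)(C)C)c1C(=O)/C=C/c1ccc(O)cc1` reaches only a limit of the assay, > 30000 nM. Compound 3 `O=C(/C=C/c1ccc(O)cc1)c1c(O)cccc1OCCC1CCCCC1` likewise stops at a limit of the assay, > 30000 nM. So compound 3 stands at the edge of what this assay can report, alongside compound 2, while compound 1 alone has a genuine number. Compound 4 `CCCCOc1cccc(O)c1C(=O)/C=C/c1ccc(O)cc1` differs from compound 3 by ethyl in place of cyclohexyl on a saturated chain carbon, two bonds along the chain from an oxygen on an aromatic ring. Among the measured compounds shown here, the one measured step that touches this place, an at least 2.7-fold higher number from compound 1 to compound 3 (0.43 log units; beyond the scatter), in which a ring replaced a branched chain, weakened inhibition. Compound 4 carries a smaller group still, so the direction of that step hints that shrinking the group might lower the number again, though nothing measured shows how far. The weight of the limit of > 30000 nM in this assay, at which 2 of the 3 values shown sit, keeps the estimate cautious. Compound 4 is therefore expected to reach 15000 nM, between 5000 nM and 40000 nM, an expected step of an at least 2.0-fold lower number from compound 3 to compound 4 (0.30 log units; that floor lies within the scatter).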

Compound 4, half-maximal inhibitory concentration: > 30000 nM
Compound 4 gave a limit, no number (the forecaster's own chance of this, stated with the estimate: 35%); middle value at least 2.0-fold (0.30 log units) from the limit.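

Compound 4 shows that making the group smaller does not recover inhibition in this assay: methyl in place of isopropyl gives an at least 2.7-fold higher number from compound 1 to compound 4 (0.43 log units; beyond the scatter). Together with an at least 2.7-fold higher number from compound 1 to compound 3 (0.43 log units; beyond the scatter), this means that the butoxy chain of compound 4 and the 2-cyclohexylethoxy chain of compound 3 both fall short of the branched chain of compound 1, so a smaller group and a larger ring both give weaker inhibition here. The step between compound 3 and compound 4 cannot be read, because each compound stops at a limit of the assay: the limit of > 30000 nM in this assay, at which 3 of the 4 values shown sit.

As far as these compounds go, what remains open is how much weaker compound 3 and compound 4 really are, and whether either differs from the other. Also open, from the compounds shown here alone, is whether an amine or a hydroxyl at the end of the chain would give a measurable number.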